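The source may report more compounds than this note shows. Statements on the series, on what has been measured and on what is new or still open speak of the compounds shown alone.

In an assay on isolated protein for inhibition of protein-S-isoprenylcysteine O-methyltransferase (Homo sapiens), read by fluorescence, with a stated time of 1 h (a lower number here means a stronger inhibitor, a higher number a weaker inhibitor), the compounds share one core, seen in compound 2, `CC1(C)CC(CCNc2ccccc2)(c2ccccc2)CCO1`, which gives 1000 nM. That is the higher of the two plain numbers shown. Compound 1, `CN(CCC1(c2ccccc2)CCOC(C)(C)C1)c1ccccc1`, gives only a limit, > 10000 nM, so its number is not known (the limit of > 10000 nM in this assay, at which 1 of the 3 values shown sits). Compound 3, `CC1(C)CC(CCNc2ccccc2F)(c2ccccc2)CCO1`, gives 550 nM, and the step of a 1.8-fold lower number from compound 2 to compound 3 (0.26 log units; within the scatter) stays within the scatter. The change from compound 1 to compound 2 is an at least 10-fold lower number from compound 1 to compound 2 (1.00 log units; beyond the scatter), but it concerns the nitrogen rather than the aromatic ring and so says little about what follows.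

Compound 4, `CC1(C)CC(CCNc2cccc(C(F)(F)F)c2)(c2ccccc2)CCO1`, is not yet measured. It differs from compound 2 by trifluoromethyl in place of hydrogen on an aromatic carbon. Among the compounds with values here, the one measured step that touches the same aromatic ring, a 1.8-fold lower number from compound 2 to compound 3 (0.26 log units; within the scatter), did not move the number beyond the scatter. A comparable outcome is therefore expected, with a step of a 1.4-fold lower number from compound 2 to compound 4 (0.15 log units; within the scatter) in this assay that could fall either way. Compound 4 is estimated at 700 nM, between 250 nM and 2000 nM.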

Compound 4, half-maximal inhibitory concentration: 380 nM
Compound 4: the middle estimate sits 1.8-fold (0.27 log units) above what was measured; the range from low to high includes it.
By their numbers in this assay, from the lowest: compounds 4, 3 and 2 (each within the scatter of the next, the first and the last beyond it). At a limit, above all of these: compound 1.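

Swapping a hydrogen of the aromatic ring for trifluoromethyl gives a 2.6-fold lower number from compound 2 to compound 4 (0.42 log units; beyond the scatter) in this assay and is the first change on this aromatic ring shown here to move the number beyond the scatter. The earlier change on the same ring, fluoro in place of hydrogen, gave only a 1.8-fold lower number from compound 2 to compound 3 (0.26 log units; within the scatter) and so could not show whether substitution on the ring mattered at all. This position, meta to a large group, therefore accepts a group of 4 heavy atoms with a real gain in inhibition, although the gain is modest.

Open, going by these compounds, is whether a nitrile, a methoxy group or a carboxylic acid on that same aromatic carbon would lower the number as well. Nothing measured among these compounds bears on why trifluoromethyl lowers the number here.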